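The source may hold more compounds than are shown below. What is called first, only, known or untested is meant among the compounds shown, and "the series" means these compounds.

In a functional assay on MDA cells (Homo sapiens) for inhibition, read by MTT assay, with a stated time of 48 h (a lower number here means a stronger inhibitor, a higher number a weaker inhibitor), compound 1 (`O=C(CCCCCCOc1no[n+]([O-])c1S(=O)(=O)c1ccccc1)NO`) gives 1210 nM and compound 2 (`O=C(CCCCCCCOc1no[n+]([O-])c1S(=O)(=O)c1ccccc1)NO`) gives 2700 nM, the higher of the two numbers, which makes compound 2 the weaker inhibitor. Compound 3 (`O=C(COCCOc1no[n+]([O-])c1S(=O)(=O)c1ccccc1)NO`) differs from it in the chain: (hydroxycarbamoyl)methoxy in place of 5-(hydroxycarbamoyl)pentyl on a saturated chain carbon, two bonds along the chain from an oxygen on an aromatic ring. Within the data shown here, only one measured step bears on this change, the modest 2.2-fold higher number from compound 1 to compound 2 (0.35 log units; beyond the scatter), where the chain grows. Among the measured compounds shown here, that hints at a slightly lower number for a shorter chain, but no measured compound carries (hydroxycarbamoyl)methoxy, so only a small drop, within the scatter, is expected in this assay. The estimated step is a 1.4-fold lower number from compound 2 to compound 3 (0.13 log units; within the scatter). The expected value for compound 3 is 2000 nM, with a range from 600 nM to 7000 nM.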

Compound 3, half-maximal inhibitory concentration: 15100 nM
Compound 3: middle estimate off by 7.6-fold (0.88 log units), on the low side; the measured number lies above the stated range.
By their numbers in this assay, from the lowest: compound 1; then compound 2; then compound 3.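

In this assay, replacing the carbon chains with (hydroxycarbamoyl)methoxy gives a 5.6-fold higher number from compound 2 to compound 3 (0.75 log units; beyond the scatter), and the gap is wider still in a 12-fold higher number from compound 1 to compound 3 (1.10 log units; beyond the scatter). This position therefore tolerates this change far less well than the earlier pair of compounds suggested, with compound 3 the weakest of the three. Nothing here explains the loss.

The entering group is both shorter and richer in oxygen, so the two differences cannot be separated. An all-carbon chain of matching length, or an amine in place of the chain oxygen, would help to tell them apart.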